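The compounds below may be only part of what the source reports. "The series", "measured", "known", "first", "only" and "open" are said of these compounds alone.

Measured so far in a functional assay on HL-60 cells (Homo sapiens) for cytotoxicity, read by ELISA, with a stated time of 2 days; on this read-out higher numbers stand for weaker inhibition and lower numbers for stronger inhibition:
- compound 1 `Oc1cccc(-c2cc(-c3ccccc3)cc(-c3ccsc3)n2)c1` gives 10300 nM
- compound 2 `Oc1cccc(-c2cc(-c3ccccc3)cc(-c3ccco3)n2)c1` gives 9910 nM
- compound 3 `Oc1cccc(-c2cc(-c3ccccc3)cc(-c3cccc(O)c3)n2)c1` gives 16400 nM

Compound 2, at 9910 nM, lies within the scatter of compound 1 and of compound 3, so no order can be read among the three.

Compound 4 `Oc1ccc(-c2cc(-c3ccccc3)cc(-c3ccco3)n2)cc1` differs from compound 2 in one place (4-hydroxyphenyl in place of 3-hydroxyphenyl on an aromatic carbon), with 4-hydroxyphenyl in place of 3-hydroxyphenyl on an aromatic carbon next to the ring nitrogen. Among the measured compounds shown here, no measured step makes this change. The closest evidence comes from swaps of the group at a different place: a 1.0-fold lower number from compound 1 to compound 2 (0.02 log units; within the scatter), a 1.6-fold higher number from compound 1 to compound 3 (0.20 log units; within the scatter) and a 1.7-fold higher number from compound 2 to compound 3 (0.22 log units; within the scatter). All three lie within the scatter, but they bear on this change only indirectly, so the range is kept wide.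

In this assay no step beyond the scatter is expected, and no direction is favoured. The estimated step is a 1.0-fold higher number from compound 2 to compound 4 (0.00 log units; within the scatter). The expected value for compound 4 is 10000 nM, with an estimated range from 4000 nM to 25000 nM.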

Compound 4, half-maximal inhibitory concentration: 3300 nM
Estimate against measurement, compound 4: 3.0-fold (0.48 log units) above, outside the stated range (below it).
By their numbers in this assay, from the lowest: compound 4; then compounds 2, 1 and 3 (each within the scatter of the next).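

In this assay, 4-hydroxyphenyl in place of 3-hydroxyphenyl on the aromatic carbon next to the ring nitrogen gives a 3.0-fold lower number from compound 2 to compound 4 (0.48 log units; beyond the scatter) and is the only step shown that lies beyond the scatter. The swaps among compound 1, compound 2 and compound 3 at a different place all stayed within the scatter, whereas here the leaving and entering groups have the same atoms and differ only in how they are joined. This shows that the series can respond to the placement of the hydroxyl on this ring, but no measurement shown explains the step.

As far as these compounds go, whether the step keeps its size with thiophen-3-yl in place of furan-2-yl remains open. Also open, from the compounds shown here alone, is how 2-hydroxyphenyl, 4-aminophenyl or 4-carboxyphenyl would compare with 4-hydroxyphenyl at this place.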